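Swapping the benzamide aryl group on a shared core

The compounds below may be only part of what the source reports. "The series", "measured", "known", "first", "only" and "open" are said of these compounds alone.

Compound 1 `CN(C)c1ccc(C(=O)Nc2ccc(Cl)c(-c3nc4ccccc4[nH]3)c2)cc1` and compound 2 `O=C(Nc1ccc(Cl)c(-c2nc3ccccc3[nH]2)c1)c1cccc(C(F)(F)F)c1` share a core and differ only in the aryl group on the carbonyl carbon. In a functional assay on Shh Light II cells for inhibition of Sonic hedgehog protein (Mus musculus), read by reporter gene assay, with a stated time of 48 h, in the presence of a further agent that is not named here (a higher number here means a weaker inhibitor, a lower number a stronger inhibitor), compound 1 gives 190 nM, while compound 2 gives 119 nM; compound 1 has the higher of the two numbers, but the gap to compound 2 lies within the scatter, so the two are read as alike. Compound 3 `COc1ccccc1C(=O)Nc1ccc(Cl)c(-c2nc3ccccc3[nH]2)c1` has not been measured in this assay. It differs from compound 1 in one place: 2-methoxyphenyl in place of 4-(dimethylamino)phenyl on a carbonyl carbon. Among the measured compounds shown here, no measured pair shows what such a change does to this assay, so compound 3 is estimated close to compound 1, with the step of a 1.1-fold higher number from compound 1 to compound 3 (0.02 log units; within the scatter) expected to stay within the scatter in either direction. On that basis compound 3 is expected to give about 200 nM in this assay, with a plausible range from 70 nM to 600 nM.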

Compound 3, half-maximal inhibitory concentration: 876 nM
For compound 3 the middle estimate is 4.4-fold (0.64 log units) below the measured one; the measured number lies above the stated range.
By their numbers in this assay, from the lowest: compounds 2 and 1 (each within the scatter of the next); then compound 3.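

The aryl group on the carbonyl carbon is not freely interchangeable: in this assay there is a 4.6-fold higher number from compound 1 to compound 3 (0.66 log units; beyond the scatter), whereas compounds 1 and 2 had read as alike despite their different aryl groups. With the shared core unchanged, 2-methoxyphenyl in place of 4-(dimethylamino)phenyl is enough to give a weaker inhibitor, even though both groups count 0 hydrogen-bond donors and 1 hydrogen-bond acceptor. Nothing available here gives a reason for this step.

The compounds shown leave open whether the loss follows the methoxy group itself or where it sits, which 4-methoxyphenyl or 2-(dimethylamino)phenyl on the same carbonyl carbon would help to separate. They also leave open how an aryl group carrying a carboxylic acid or a primary amine would read in this assay.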